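Swapping 2-fluorophenyl for 4-methylphenyl on an amide nitrogen

The compounds below may be only part of what the source reports. "The series", "measured", "known", "first", "only" and "open" are said of these compounds alone.

Measured in a functional assay on OVCAR-5 cells (Homo sapiens) for inhibition, read by CCK-8 assay, with a stated time of 72 h, tested at 10 uM; a lower number here means less inhibition of growth, a higher number more inhibition of growth at the concentration tested:
Compound 1 `CN(C)C(=O)c1cc2cnc(Nc3ccc(NC(=O)C4(C(=O)Nc5ccc(F)cc5)CC4)cc3)nc2n1C1CCCC1`: 79.7%
Compound 2 `CN(C)C(=O)c1cc2cnc(Nc3ccc(NC(=O)C4(C(=O)Nc5ccccc5F)CC4)cc3)nc2n1C1CCCC1`: 82.6%
Compound 3 `Nc1ccc(NC(=O)C2(C(=O)Nc3ccc(F)cc3)CC2)cc1F`: 9.7%

Compound 2 lies within the usual scatter of compound 1, and compound 3 lies far lower than both. The next molecule, compound 4 `Cc1ccc(NC(=O)C2(C(=O)Nc3ccc(Nc4ncc5cc(C(=O)N(C)C)n(C6CCCC6)c5n4)cc3)CC2)cc1`, differs from compound 2 in one place: 4-methylphenyl in place of 2-fluorophenyl on an amide-type nitrogen. That is, 4-methylphenyl stands in place of 2-fluorophenyl on an amide-type nitrogen. For the measured compounds named here, only one measured step touches this place: a number 2.9 percentage points higher from compound 1 to compound 2 (within the scatter). Going by the values given here, it exchanged one fluorophenyl for another, so it is only a loose guide, and no measured compound carries 4-methylphenyl. With that single small step as evidence, no change beyond the scatter is expected in this assay. The expected step is a number 2.6 percentage points lower from compound 2 to compound 4 (within the scatter). For compound 4 the estimated value is 80%, with an expected range of 66% to 90%.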

Compound 4, percent growth inhibition at one concentration: 80.6%
Beside the measured number, compound 4's estimate is 0.6 percentage points below it; the measured number falls inside the stated range.
By their numbers in this assay, from the lowest: compound 3; then compounds 1, 4 and 2 (each within the scatter of the next).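

In this assay, the group on this amide-type nitrogen can be 4-methylphenyl as well as a fluorophenyl, since both new steps stay within the scatter (a number 2 percentage points lower from compound 2 to compound 4 (within the scatter); a number 0.9 percentage points higher from compound 1 to compound 4 (within the scatter)). Fluorine is therefore not needed on this ring to keep growth inhibition at this level, at least among compounds 1, 2 and 4. Nothing available explains why these groups read alike.

Still open, on these data alone, is whether this tolerance extends to a phenyl ring carrying a carboxylic acid or an amine. The same question applies to a saturated cyclohexyl ring on this nitrogen.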